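Moving the fluorine: 4-fluorophenyl to 2-fluorophenyl

The source may hold more compounds than are shown below. What is called first, only, known or untested is meant among the compounds shown, and "the series" means these compounds.

Of the compounds shown here, two have numbers so far in a functional assay for inhibition, with Homo sapiens as the target; on this read-out lower numbers stand for tighter binding and higher numbers for weaker binding. Compound 1 (`COc1ccc(OC(C)(C)C2OCC(C/C=C\CCC(=O)O)C(c3cccnc3)O2)cc1`) gives 302 nM, and compound 2 (`CC(C)(Oc1ccc(F)cc1)C1OCC(C/C=C\CCC(=O)O)C(c2cccnc2)O1`) gives 120 nM, the lower of the two. Compound 3 (`CC(C)(Oc1ccccc1F)C1OCC(C/C=C\CCC(=O)O)C(c2cccnc2)O1`) has not yet been measured. It has the same atoms as compound 2, joined differently: 2-fluorophenyl in place of 4-fluorophenyl on an oxygen on a saturated carbon. Here 2-fluorophenyl stands in place of 4-fluorophenyl on an oxygen on a saturated carbon. Going by the values given here, only one measured step bears on this: a 2.5-fold lower number from compound 1 to compound 2 (0.40 log units; beyond the scatter), a modest step with fluoro in place of methoxy on an aromatic carbon. That step swaps one group for another rather than relocating a fluorine, so it offers no firm direction here. The expected change is therefore small, an estimated 1.3-fold higher number from compound 2 to compound 3 (0.10 log units; within the scatter). For compound 3 the expected value is 150 nM, with an estimated range of 60 nM to 380 nM.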

Compound 3, dissociation constant: 166 nM
Compound 3: middle estimate off by 1.1-fold (0.04 log units), on the low side; the measured number falls inside the stated range.
By their numbers in this assay, from the lowest: compounds 2, 3 and 1 (each within the scatter of the next, the first and the last beyond it).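

In this assay the fluorine can sit as 4-fluorophenyl or as 2-fluorophenyl on this oxygen without a reading that separates the two (a 1.4-fold higher number from compound 2 to compound 3 (0.14 log units; within the scatter)). Compound 3 also stays within the scatter of compound 1, where 2-fluorophenyl stands in place of 4-methoxyphenyl (a 1.8-fold lower number from compound 1 to compound 3 (0.26 log units; within the scatter)), so unlike compound 2 it cannot be told apart from the methoxy compound. No measurement is available to explain why these numbers fall as they do.

As far as these compounds go, whether the fluorine contributes at all remains open, as a plain phenyl with no fluorine would be needed to answer that. From the compounds shown here alone, whether a chlorophenyl or a cyanophenyl on the same oxygen would read the same in this assay also remains unknown.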